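Swapping the amide ring on a bis-hydroxylated tetrahydrofuran chain

The compounds below may be only part of what the source reports. "The series", "measured", "known", "first", "only" and "open" are said of these compounds alone.

Measured compounds:
compound 1 `CCCCCCCCCCCC[C@@H](O)[C@H]1CC[C@H]([C@H](O)CCCCCCCCCCNC(=O)c2ccsc2)O1` gives 3020 nM in a functional assay on KM12 cells (Homo sapiens) for inhibition, read by colorimetric assay and sulforhodamine B assay, with a stated time of 48 h; a higher number here means a weaker inhibitor of growth, a lower number a stronger inhibitor of growth
compound 2 `CCCCCCCCCCCC[C@@H](O)[C@H]1CC[C@H]([C@H](O)CCCCCCCCCCNC(=O)c2ccnn2C)O1` gives 100000 nM in this assay

Among the measured compounds shown here, compound 2 holds the highest of the two numbers, standing a 33-fold higher number from compound 1 to compound 2 (1.52 log units; beyond the scatter) away from compound 1; the only measured step thus runs toward weaker growth inhibition when the thiophen-3-yl ring is replaced. Compound 3 `CCCCCCCCCCCC[C@@H](O)[C@H]1CC[C@H]([C@H](O)CCCCCCCCCCNC(=O)c2ccco2)O1` is not yet measured. It differs from compound 2 by furan-2-yl in place of 1-methyl-1H-pyrazol-5-yl on a carbonyl carbon. Like the ring in compound 1, the entering ring is a five-membered aromatic with one hetero atom, so the step from compound 1 to compound 2 is the one that bears here, run in reverse. Compound 3 is therefore expected to move back toward the number of compound 1, with an estimated 25-fold lower number from compound 2 to compound 3 (1.40 log units; beyond the scatter). Compound 3 is estimated at 4000 nM, between 1500 nM and 20000 nM.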

Compound 3, concentration for 50% growth inhibition: 100000 nM
Compound 3: middle estimate off by 25-fold (1.40 log units), on the low side, outside the stated range (above it).
By their numbers in this assay, from the lowest: compound 1; then compounds 2 and 3 (each within the scatter of the next).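

Changing the ring from 1-methyl-1H-pyrazol-5-yl to furan-2-yl in this assay gives no change at the digits printed from compound 2 to compound 3 (within the scatter), whereas changing thiophen-3-yl to furan-2-yl gives a 33-fold higher number from compound 1 to compound 3 (1.52 log units; beyond the scatter). The large loss in growth inhibition seen with compound 2 is therefore not confined to that ring: a five-membered aromatic ring with one hetero atom on this carbonyl carbon does not by itself keep the number of compound 1, and among these three rings only thiophen-3-yl gives the lower number. Nothing available explains this difference between the thiophene and furan rings.

Thiophen-2-yl and furan-3-yl could show whether the hetero atom or the ring's point of attachment matters more. A phenyl ring would show whether any hetero atom is needed here at all.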